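This account rests on a few compounds, and the source may have more. Where it says the series, first, only, none or still open, it means among the compounds named here.

Measured compounds in a functional assay on MCF7 cells (Homo sapiens) for inhibition, read by MTT assay, with a stated time of 24 h; a higher number here means a weaker inhibitor, a lower number a stronger inhibitor:
- compound 1 `CCOC(=O)c1c(C)[nH]c(=O)c(C#N)c1-c1ccc(OC)cc1`: 36100 nM
- compound 2 `CCOC(=O)c1c(C)[nH]c(=O)c(C#N)c1-c1ccc([N+](=O)[O-])cc1`: 82000 nM
- compound 3 `CCOC(=O)c1c(C)[nH]c(=O)c(C#N)c1-c1ccc(F)cc1`: 22900 nM

On these numbers compound 2 stands highest of the three: from compound 1 to compound 2 the change is a 2.3-fold higher number from compound 1 to compound 2 (0.36 log units; beyond the scatter), and from compound 2 to compound 3 it is a 3.6-fold lower number from compound 2 to compound 3 (0.55 log units; beyond the scatter). The values of compound 1 and compound 3 lie within the scatter of each other, so no order between them is claimed.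

Compound 4 `CCOC(=O)c1c(C)[nH]c(=O)c(C#N)c1-c1ccc(Br)cc1` is not yet measured. It differs from compound 2 by bromo in place of nitro on an aromatic carbon. Going by the values given here, two measured steps bear on this: the step from compound 2 to compound 3, which also removes the nitro group and puts a halogen in its place, gave a 3.6-fold lower number from compound 2 to compound 3 (0.55 log units; beyond the scatter); the step from compound 1 to compound 2, which introduced the nitro group, gave a 2.3-fold higher number from compound 1 to compound 2 (0.36 log units; beyond the scatter). Both point the same way: the compound carrying the nitro group gives the higher number. Swapping it for a halogen is therefore expected to lower the number in this assay by about the size of the step from compound 2 to compound 3, the estimated step being a 3.7-fold lower number from compound 2 to compound 4 (0.57 log units; beyond the scatter). Among the compounds with values here, with only one halogen example in hand the range is kept wide. For compound 4 the estimate in this assay is 22000 nM, between 9000 nM and 55000 nM.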

Compound 4, half-maximal inhibitory concentration: 31800 nM
Beside the measured number, compound 4's estimate is 1.4-fold (0.16 log units) below it; low and high end bracket the measured number.
By their numbers in this assay, from the lowest: compounds 3, 4 and 1 (each within the scatter of the next); then compound 2.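

In this assay a second halogen at this place, on the aromatic carbon para to a large group, also gives a lower number than nitro (a 2.6-fold lower number from compound 2 to compound 4 (0.41 log units; beyond the scatter)), so the fall seen with fluoro is not confined to that one halogen. Bromo cannot be separated from fluoro (a 1.4-fold higher number from compound 3 to compound 4 (0.14 log units; within the scatter)) or from methoxy (a 1.1-fold lower number from compound 1 to compound 4 (0.06 log units; within the scatter)), which leaves compound 2 as the only one of the four standing apart, with no order among the other three. No measurement at hand bears on what lies behind this pattern.

Open, going by these compounds, is whether an amine or a carboxylic acid at this place would group with the halogens and methoxy or with nitro. Also open, on these data alone, is whether a longer chain on the ester would shift the numbers of the whole set.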